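Aryl imine replacing the ester imine: estimate for compound 4

This account rests on a few compounds, and the source may have more. Where it says the series, first, only, none or still open, it means among the compounds named here.

Measured compounds:
compound 1 `CCOC(=O)/C=N/c1cnc(Nc2ccc(N3CCN(C)CC3)cc2)nc1NC1CCCC1` 15100 nM
compound 2 `NS(=O)(=O)c1ccc(Nc2ncc(/N=C/c3cccs3)c(NC3CCCC3)n2)cc1` 9950 nM
compound 3 `CCOC(=O)/C=N/c1cnc(Nc2ccc(N3CCN(C)CC3)cc2)nc1NC(C)C` 7590 nM

In a functional assay on HT-29 cells (Homo sapiens) for antiproliferative activity, read by MTT assay (on this read-out higher numbers stand for weaker inhibition and lower numbers for stronger inhibition), compound 3 holds the lowest of the three numbers, but compound 2 and compound 1 both sit within the scatter of it, so no order among them is secure. For the measured compounds named here, the single one-place step measured, a 2.0-fold lower number from compound 1 to compound 3 (0.30 log units; within the scatter), concerns the nitrogen on the aromatic ring, not the imine carbon, and is itself within the scatter. Compound 4 `CC(C)Nc1nc(Nc2ccc(N3CCN(C)CC3)cc2)ncc1/N=C/c1ccc(C(F)(F)F)cc1` arises from compound 3 by 4-(trifluoromethyl)phenyl in place of ethoxycarbonyl on a carbon with a double bond to nitrogen. Going by the values given here, no measured step bears on this position; compound 2 carries an aryl imine and a number close to that of compound 3, yet it also differs at the aniline, so it gives only a loose hint that an aryl imine is tolerated. The expected step of a 1.4-fold lower number from compound 3 to compound 4 (0.14 log units; within the scatter) therefore lies within the scatter. Compound 4 is estimated at 5500 nM, with a range from 1500 nM to 20000 nM.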

Compound 4, half-maximal inhibitory concentration: > 100000 nM
Compound 4: only a limit was reported; the forecaster's own chance of this, stated with the estimate: 5%; at least 18-fold (1.25 log units) between middle value and limit.
By their numbers in this assay, from the lowest: compounds 3, 2 and 1 (each within the scatter of the next). At a limit, above all of these: compound 4.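

On a carbon with a double bond to nitrogen, 4-(trifluoromethyl)phenyl in place of ethoxycarbonyl gives an at least 13-fold higher number from compound 3 to compound 4 (1.11 log units; beyond the scatter) in this assay. For the compounds shown here, this is the first one-place step at this position, and it shows that the position does not accept every replacement. The result for compound 4 is a limit, not a number: the limit of > 100000 nM in this assay, at which 1 of the 4 values shown sits.

Still open, going by these compounds, is whether the loss follows from the aromatic ring itself or from its trifluoromethyl group. An unsubstituted phenyl or a 4-methoxyphenyl on this carbon, with the rest of compound 3 unchanged, would separate the two.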